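Extending the chain and dropping the azide in an H2 antagonist series

This account rests on a few compounds, and the source may have more. Where it says the series, first, only, none or still open, it means among the compounds named here.

Of the compounds shown here, two sharing one core have been measured in a functional assay on cardiac atrium for antagonist activity at histamine H2 receptor (Cavia porcellus); a higher number here means a more potent compound, by a factor of ten per unit of this negative logarithm, a lower number a less potent compound. Compound 1, with the structure `N#CN/C(=N\CCCNc1ccc(N=[N+]=[N-])cc1[N+](=O)[O-])NCCCCOc1cccc(CN2CCCCC2)c1`, gives 6.56 in this assay. Compound 2, with the structure `N#CN/C(=N\CCCNC(=O)c1ccc(N=[N+]=[N-])cc1)NCCCOc1cccc(CN2CCCCC2)c1`, gives 6.36 in this assay. These two values lie within the usual scatter of each other, so neither compound can be called the more potent; compound 2 simply sits alongside compound 1 on the numbers shown.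

Compound 3, with the structure `N#CN/C(=N\CCCCCCNC(=O)c1ccccc1)NCCCOc1cccc(CN2CCCCC2)c1`, has not yet been measured. It differs from compound 2 in one place: 3-benzamidopropyl in place of ((4-azidophenyl)carbonyl)amino on a saturated chain carbon, three bonds along the chain from a double-bonded nitrogen. In plain terms, the aryl azide is gone and the amide now sits further out along a longer chain, with a plain benzene ring at its end.

Among the measured compounds shown here, no measured pair in this set isolates such a change, so the direction of the step is uncertain. The expectation is a small step from compound 2 to compound 3 of a number 0.06 log units lower from compound 2 to compound 3 (within the scatter), not clearly beyond the scatter. Compound 3 is therefore estimated to give about 6.3 in this assay, with a likely range from 5.7 to 6.9.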

Compound 3, negative logarithm of the antagonist equilibrium constant: 6.6
Compound 3: middle estimate off by 0.30 log units, on the low side, and the stated range covers the measured number.
By their numbers in this assay, from the lowest: compounds 2, 1 and 3 (each within the scatter of the next).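

In this assay, placing 3-benzamidopropyl where ((4-azidophenyl)carbonyl)amino stood, on a saturated chain carbon, three bonds along the chain from a double-bonded nitrogen, gives a step of a number 0.24 log units higher from compound 2 to compound 3 (within the scatter), so the two compounds cannot be told apart on these numbers. Among the compounds shown here, this is the first direct look at this position, and in this single pair it accepts a large rewrite: the azide is gone, the amide sits further out along the chain, and both groups still count 12 heavy atoms and one benzene ring, with no clear change in the read-out. Nothing measured alongside these numbers offers an explanation for how the two groups compare.

From the compounds shown here alone, the step also bundles two changes, so it remains open what each does alone: the plain benzamide on the shorter chain of compound 2, or the 4-azidobenzamide on the longer chain of compound 3, would separate them. Also open, going by these compounds, is how this position responds to a different group at the end of the chain, such as an amine or a carboxylic acid in place of the benzamide.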